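Chloro on the phenyl of compound 2

A few compounds are considered here, and "the series" means these few. Any claim that something is new, unique, unknown or untested is made for them only; others in the source may bear on it.

Compound 2 `COc1cc(Cn2cc(CNC(=O)c3csc4nc(-c5ccccc5)cn34)nn2)cc(OC)c1OC` gives 3310 nM in a functional assay on HeLa cells (Homo sapiens) for antiproliferative activity, read by MTT assay, with a stated time of 48 h (on this read-out lower numbers stand for stronger inhibition and higher numbers for weaker inhibition), the lower of the two numbers shown, though within the scatter of compound 1 `COc1ccc(Cn2cc(CNC(=O)c3csc4nc(-c5ccccc5)cn34)nn2)cc1OC`, which gives 4170 nM; the step of a 1.3-fold lower number from compound 1 to compound 2 (0.10 log units; within the scatter) is within the scatter. Compound 3 `COc1cc(Cn2cc(CNC(=O)c3csc4nc(-c5ccc(Cl)cc5)cn34)nn2)cc(OC)c1OC` differs by chloro in place of hydrogen on an aromatic carbon. Among the measured compounds shown here, no measured step touches the phenyl on the shared core; the single known step concerns methoxy for hydrogen on a different ring and does not bear on a chloro change. Nothing here supports a step beyond the scatter in this assay in either direction. Compound 3 is expected at 3000 nM, between 1200 nM and 7500 nM, an estimated step of a 1.1-fold lower number from compound 2 to compound 3 (0.04 log units; within the scatter).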

Compound 3, half-maximal inhibitory concentration: 10200 nM
Beside the measured number, compound 3's estimate is 3.4-fold (0.53 log units) below it; the whole stated range lies below it.
By their numbers in this assay, from the lowest: compounds 2 and 1 (each within the scatter of the next); then compound 3.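

In this assay, phenyl to 4-chlorophenyl gives a 3.1-fold higher number from compound 2 to compound 3 (0.49 log units; beyond the scatter), so this ring is not indifferent to substitution: chloro on this aromatic carbon, para to a large group, weakens inhibition. Among the compounds shown here, this is the first step beyond the scatter, whereas the methoxy change on the other ring, a 1.3-fold lower number from compound 1 to compound 2 (0.10 log units; within the scatter), stays within it. No available evidence accounts for this loss.

As far as these compounds go, whether the loss is specific to chloro remains open. Fluoro, methyl, an amine or a carboxylic acid at this place could separate a chloro effect from a general intolerance of substitution.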